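Notes on a side-chain exchange, compound 3 to compound 4

This account rests on a few compounds, and the source may have more. Where it says the series, first, only, none or still open, it means among the compounds named here.

Measured in a functional assay on HCT-116 cells (Homo sapiens) for cytotoxicity; on this read-out lower numbers stand for stronger inhibition and higher numbers for weaker inhibition:
- compound 1 `COc1cc(N2CCN(CC3CCOC3)CC2)ccc1Nc1nc(NC2CCCCC2)c2nc[nH]c2n1` gives 66 nM
- compound 2 `COc1cc(N2CCC(C(=O)N3CCC(N(C)C)C3)CC2)ccc1Nc1nc(NC2CCCCC2)c2nc[nH]c2n1` gives 58 nM
- compound 3 `COc1cc(N2CCC(CC(=O)N3CCN(C)CC3)CC2)ccc1Nc1nc(NC2CCCCC2)c2nc[nH]c2n1` gives 51 nM

The three values lie within the scatter of one another, so compound 3 cannot be ranked against compound 1 or compound 2 on these numbers.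

The next compound to be measured is compound 4 `CCN(CC)CC1CCN(c2ccc(Nc3nc(NC4CCCCC4)c4nc[nH]c4n3)c(OC)c2)CC1`. It differs from compound 3 by diethylamino in place of (4-methylpiperazin-1-yl)carbonyl on a saturated chain carbon bound to a saturated ring carbon.

Going by the values given here, no measured step covers this exact exchange. The nearest evidence is a 1.1-fold lower number from compound 2 to compound 3 (0.06 log units; within the scatter), a step that replaces one side group with another on a saturated ring carbon and stays within the scatter. Compound 1, with a different side group again, gives a value that is also within the scatter of the other two. Across these three compounds, then, changing the side group has not moved the number measurably, and no compound among them goes against this. Three compounds are a small basis, and none of them carries the diethylamino group.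

In this assay, the expected change is a 1.1-fold higher number from compound 3 to compound 4 (0.03 log units; within the scatter), with no shift beyond the scatter anticipated in either direction.

For compound 4 the estimated value is 55 nM, with an expected range from 20 nM to 130 nM.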

Compound 4, half-maximal inhibitory concentration: 74 nM
Estimate against measurement, compound 4: 1.3-fold (0.13 log units) below, and the stated range covers the measured number.
By their numbers in this assay, from the lowest: compounds 3, 2, 1 and 4 (each within the scatter of the next).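

In this assay, the exchange at the saturated chain carbon bound to a saturated ring carbon removes the carbonyl and the six-membered ring of (4-methylpiperazin-1-yl)carbonyl and puts the smaller, ringless diethylamino in their place, yet the step stays within the scatter (a 1.5-fold higher number from compound 3 to compound 4 (0.16 log units; within the scatter)). The two wider comparisons also stay within the scatter, both the change to (diethylamino)methyl on a saturated ring carbon (a 1.3-fold higher number from compound 2 to compound 4 (0.11 log units; within the scatter)) and the change to 4-((diethylamino)methyl)piperidin-1-yl on an aromatic carbon (a 1.1-fold higher number from compound 1 to compound 4 (0.05 log units; within the scatter)), so the flat picture now extends to a side group with neither a carbonyl nor a ring, and none of the four compounds goes against it. No measurement at hand accounts for this lack of movement.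

Going by these compounds, all four side groups contain nitrogen, so it stays open whether a carboxylic acid, a hydroxyl group or a plain alkyl chain at this position would shift the number beyond the scatter. The methoxy group and the cyclohexylamino group are the same throughout, so these results say nothing about how far the number depends on either.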